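Changing One Aryl Group on a Shared Core

The compounds below may be only part of what the source reports. "The series", "measured", "known", "first", "only" and "open" are said of these compounds alone.

Within the data shown here, in a functional assay on HeLa cells (Homo sapiens) for antiproliferative activity, read by MTT assay, with a stated time of 48 h (a higher number here means a weaker inhibitor, a lower number a stronger inhibitor), compound 2 `Cc1cccc(-c2nn(-c3ccccc3)cc2C(Nc2nc3ccccc3s2)c2c(O)ccc3ccccc23)c1` gives 7020 nM, the lower of the two numbers so far, while compound 1 `COc1cccc(-c2nn(-c3ccccc3)cc2C(Nc2nc3ccccc3s2)c2c(O)ccc3ccccc23)c1` gives 14900 nM. Compound 3 `O=[N+]([O-])c1ccc(-c2nn(-c3ccccc3)cc2C(Nc2nc3ccccc3s2)c2c(O)ccc3ccccc23)cc1` carries 4-nitrophenyl in place of 3-methylphenyl, on an aromatic carbon of a five-membered aromatic ring with 2 nitrogen: 4-nitrophenyl in place of 3-methylphenyl on an aromatic carbon. Among the measured compounds shown here, the only measured guide is the modest 2.1-fold lower number from compound 1 to compound 2 (0.33 log units; beyond the scatter), which involved methyl in place of methoxy. A step no larger than that is therefore expected, slightly upward if anything. The estimated change is a 1.3-fold higher number from compound 2 to compound 3 (0.11 log units; within the scatter). Compound 3 is expected near 9000 nM, with an estimated range of 3000 nM to 27000 nM.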

Compound 3, half-maximal inhibitory concentration: 6810 nM
Compound 3: the middle estimate sits 1.3-fold (0.12 log units) above what was measured; the measured number falls inside the stated range.
By their numbers in this assay, from the lowest: compounds 3 and 2 (each within the scatter of the next); then compound 1.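

At this position on the shared core, 4-nitrophenyl and 3-methylphenyl cannot be told apart in this assay: the change gives a 1.0-fold lower number from compound 2 to compound 3 (0.01 log units; within the scatter), even though the two groups differ in their atoms and in hydrogen-bond acceptors. Set against 3-methoxyphenyl, 4-nitrophenyl gives a 2.2-fold lower number from compound 1 to compound 3 (0.34 log units; beyond the scatter), a modest step of about the same size as the one seen with 3-methylphenyl. Nothing measured here explains these numbers.

As far as these compounds go, whether an aryl ring carrying an amine or a carboxylic acid would fit these results stays open. So does the effect of moving the nitro group around the ring, which would separate the group's identity from its place.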